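The compounds below may be only part of what the source reports. "The series", "measured", "known", "first", "only" and "open" are said of these compounds alone.

In a functional assay on HL-60 cells (Homo sapiens) for cytotoxicity, read by MTT assay (a higher number here means a weaker inhibitor, a lower number a stronger inhibitor), compound 1 (`COc1ccc(S(=O)(=O)NC(C2=CC(=O)c3c(O)ccc(O)c3C2=O)C(C)C)cc1`) stands as "not determined" (no result reported), while compound 2 (`CC(=O)c1ccc(S(=O)(=O)NC(C2=CC(=O)c3c(O)ccc(O)c3C2=O)C(C)C)cc1`) gives 110 nM and compound 3 (`CCOC(=O)c1ccc(S(=O)(=O)NC(C2=CC(=O)c3c(O)ccc(O)c3C2=O)C(C)C)cc1`) gives 150 nM. For the measured compounds named here, compound 3 therefore sits level with compound 2, the only other number available. Compound 4 (`CCOC(=O)c1ccc(S(=O)(=O)NC(C)C2=CC(=O)c3c(O)ccc(O)c3C2=O)cc1`) carries methyl in place of isopropyl on a saturated chain carbon bound to a double-bonded ring carbon and a sulfonamide nitrogen. Going by the values given here, the single measured step, a 1.4-fold higher number from compound 2 to compound 3 (0.13 log units; within the scatter), swaps ethoxy for methyl on a carbonyl carbon and does not touch this place, so it is only a loose guide. No direction can be drawn from the data, and no shift beyond the scatter is expected in this assay. The expected change is a 1.1-fold higher number from compound 3 to compound 4 (0.05 log units; within the scatter). For compound 4 the estimated value is 170 nM, with an expected range of 60 nM to 450 nM.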

Compound 4, half-maximal inhibitory concentration: 120 nM
Compound 4: middle estimate off by 1.4-fold (0.15 log units), on the high side; the range from low to high includes it.
By their numbers in this assay, from the lowest: compounds 2, 4 and 3 (each within the scatter of the next).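

In this assay, for the compounds shown here, the first change at this position, methyl in place of isopropyl on a saturated chain carbon bound to a double-bonded ring carbon and a sulfonamide nitrogen, gives a 1.3-fold lower number from compound 3 to compound 4 (0.10 log units; within the scatter) and so stays within the scatter. For this pair, the two fewer carbons in the group at this place leave the cytotoxicity reading effectively unmoved. Nothing available accounts for this result. The compounds shown leave open whether a longer chain, a phenyl ring or an amine at this place would shift the number beyond the scatter. They also leave open whether the same swap would behave alike with the acetyl group of compound 2 on the shared core.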